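The source may report more compounds than this note shows. Statements on the series, on what has been measured and on what is new or still open speak of the compounds shown alone.

Measured so far:
compound 1 `O=C(NNc1ccccc1F)c1ccc(NS(=O)(=O)c2cnc(O)nc2O)cc1` — 16000 nM
compound 2 `Cc1cccc(NNC(=O)c2cccc(NS(=O)(=O)c3cnc(O)nc3O)c2)c1` — > 20000 nM (a limit)
compound 3 `O=C(NNC(=O)c1ccccc1F)c1ccc(NS(=O)(=O)c2cnc(O)nc2O)cc1` — > 20000 nM (a limit)

In a functional assay on SGC-7901 cells (Homo sapiens) for antiproliferative activity, read by MTT assay, with a stated time of 24 h (a lower number here means a stronger inhibitor, a higher number a weaker inhibitor), compound 1 gives 16000 nM. For compound 2 the value is only a limit of the assay, > 20000 nM. Compound 3 likewise stops at a limit, > 20000 nM. Compound 2 thus stands at the weak end of the series without a number of its own; (the limit of > 20000 nM in this assay, at which 2 of the 3 values shown sit).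

Compound 4 `O=C(NNC(=O)c1cccc(NS(=O)(=O)c2cnc(O)nc2O)c1)c1cccc(Cl)c1` is not yet measured. It differs from compound 2 in one place: (3-chlorophenyl)carbonyl in place of 3-methylphenyl on an amine nitrogen. Going by the values given here, the one measured step that bears on it is an at least 1.2-fold higher number from compound 1 to compound 3 (0.09 log units; that floor lies within the scatter), the same kind of exchange on the amine nitrogen, and it ended at a limit. Starting from a limit, compound 4 is expected to stay at or beyond it, so the step that the limit leaves unreadable from compound 2 to compound 4 is expected to be none beyond the scatter. The estimate for compound 4 is 30000 nM, ranging from 14000 nM to 80000 nM.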

Compound 4, half-maximal inhibitory concentration: 7310 nM
The estimate for compound 4 lay 4.1-fold (0.61 log units) above the measured number; the measured number lies below the stated range.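

In this assay, (3-chlorophenyl)carbonyl in place of 3-methylphenyl on the amine nitrogen gives an at least 2.7-fold lower number from compound 2 to compound 4 (0.43 log units; beyond the scatter), so a carbonyl-linked aryl group at this position is compatible with a measured number. The earlier exchange of this kind gave only an at least 1.2-fold higher number from compound 1 to compound 3 (0.09 log units; that floor lies within the scatter), which showed no such drop. The size of the new step is only a floor: the limit of > 20000 nM in this assay, at which 2 of the 4 values shown sit.

The step changes both the carbonyl and the ring substituent, so the two contributions remain unseparated. A (3-methylphenyl)carbonyl or a 3-chlorophenyl on the same nitrogen would separate them.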